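The compounds below may be only part of what the source reports. "The series", "measured", "known", "first", "only" and "open" are said of these compounds alone.

Working notes on the series. In an in vivo ADME assay on the whole organism (strain Mongrel) for metabolic stability, with Canis familiaris (Canis lupus familiaris) as the target (on this read-out higher numbers stand for a longer-lived compound and lower numbers for a shorter-lived compound), compound 1 `COc1ncc(C(=O)NC2(C(=O)N[C@H](C)c3ccc(-n4nc(Cl)c5ccccc54)cc3F)CC2)s1` gives 8.3 h. In this assay compound 2 `C[C@@H](NC(=O)C1(NC(=O)c2ccc(Br)nc2)CC1)c1ccc(-n2nc(Cl)c3ccccc32)cc1F` gives 7.1 h. Among the compounds with values here, the single step so far, a 1.2-fold lower number from compound 1 to compound 2 (0.07 log units; within the scatter), exchanges one aromatic group on the carbonyl carbon for another and does not move the number beyond the scatter. Compound 2 stands at the lowest of the two numbers, with compound 1 nearest, and the two values lie within the scatter of each other, so no order between them is read.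

Compound 3 `C[C@@H](NC(=O)C1(NC(=O)c2cncc(Cl)n2)CC1)c1ccc(-n2nc(Cl)c3ccccc32)cc1F` has no number yet in this assay. Its change from compound 2 is 6-chloropyrazin-2-yl in place of 6-bromopyridin-3-yl on a carbonyl carbon. Within the data shown here, the only step that bears on it is the one from compound 1 to compound 2, the same kind of exchange at the same carbonyl carbon, and it was within the scatter. On that basis no step beyond the scatter is expected in this assay for compound 3, in either direction. The expected step is a 1.1-fold lower number from compound 2 to compound 3 (0.04 log units; within the scatter). Compound 3 is expected to give 6.5 h. For compound 3 the lower end of the estimate is 3.5 h. For compound 3 the upper end of the estimate is 12 h.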

Compound 3, half-life: 15.1 h
Estimate against measurement, compound 3: 2.3-fold (0.37 log units) below, and the stated range ends below it.
By their numbers in this assay, from the lowest: compounds 2, 1 and 3 (each within the scatter of the next, the first and the last beyond it).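

In this assay, within the data shown here, the exchange on the carbonyl carbon gives a 2.1-fold higher number from compound 2 to compound 3 (0.33 log units; beyond the scatter) and so is the first step at this place to pass the scatter, which means the choice of aromatic group here can move the number, if only modestly. The same group set against 2-methoxy-1,3-thiazol-5-yl gives a 1.8-fold higher number from compound 1 to compound 3 (0.26 log units; within the scatter) and stays inside the scatter, so 6-chloropyrazin-2-yl is separated from 6-bromopyridin-3-yl alone, and compound 1 cannot be ordered against either compound 2 or compound 3. Nothing at hand bears on what lies behind the step from 6-bromopyridin-3-yl to 6-chloropyrazin-2-yl.

That step changes the ring hetero atoms and the halogen together, so the compounds shown cannot assign it to either one, and a 6-chloropyridin-3-yl or a 6-bromopyrazin-2-yl group would be needed to take the two apart. As far as these compounds go, it also remains open whether the halogen is needed at all on this ring, as an unsubstituted pyrazin-2-yl group or a pyrazine bearing an amine or a methoxy group would show.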